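Methyl removal on a pyridine ring: two thiosemicarbazide pairs

The source may report more compounds than this note shows. Statements on the series, on what has been measured and on what is new or still open speak of the compounds shown alone.

Measured compounds:
Compound 1 `N/C(=N\NC(=S)N1CCOCC1)c1ccccn1`: 40%
Compound 2 `Cc1ccnc(/C(N)=N/NC(=S)N2CCOCC2)c1`: 44.7%
Compound 3 `Cc1cccc(/C(N)=N/NC(=S)N2CCCC2)n1`: 56.8%

In a functional assay on HeLa cells (Homo sapiens) for cytotoxicity, read by MTT assay, with a stated time of 72 h, tested at 3 uM (on this read-out lower numbers stand for less inhibition of growth and higher numbers for more inhibition of growth at the one concentration tested), compound 3 gives the highest of the three numbers, compound 2 stands nearer and compound 1 furthest below it. The difference between the core of compound 3 and the core of compound 2 is not broken down here. Compound 4 `N/C(=N\NC(=S)N1CCCC1)c1ccccn1` is not yet measured. It is related to compound 3 by hydrogen in place of methyl on an aromatic carbon, the same kind of change as that from compound 2 to compound 1, (hydrogen in place of methyl on an aromatic carbon), though in compound 2 the methyl sits opposite the ring nitrogen, in compound 3 next to the ring nitrogen. That earlier step was a number 4.7 percentage points lower from compound 2 to compound 1 (within the scatter). Resting on that step, compound 4 is expected to lie close to compound 3, with an estimated a number 4.8 percentage points lower from compound 3 to compound 4 (within the scatter), giving an expected value of 52% with a range from 38% to 66%.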

Compound 4, percent growth inhibition at one concentration: 38.5%
The estimate for compound 4 lay 13.5 percentage points above the measured number; the range from low to high includes it.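

In this assay, hydrogen in place of methyl on an aromatic carbon gives a number 18.3 percentage points lower from compound 3 to compound 4 (beyond the scatter), and pyrrolidin-1-yl in place of morpholin-4-yl on a thiocarbonyl carbon gives a number 1.5 percentage points lower from compound 1 to compound 4 (within the scatter). Set beside the earlier methyl step, the new step cannot be told apart from it, so carrying the change between these two cores is not contradicted: the same change on two cores in this assay, a number 4.7 percentage points lower (within the scatter) from compound 2 to compound 1 and a number 18.3 percentage points lower (beyond the scatter) from compound 3 to compound 4, 13.6 percentage points apart, within the scatter of two such steps. This does not show that the step has one fixed size across cores, and the methyl sits at a different place in the two pairs.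

On these data alone, it remains open whether an ethyl or a methoxy group on the same aromatic carbon would follow the methyl. Also open is how a piperidin-1-yl group on the thiocarbonyl carbon would compare with the two rings shown.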